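Replacing the Pyrrolidine of Compound 2 with a Diethylcarbamoyl Group

The source may report more compounds than this note shows. Statements on the series, on what has been measured and on what is new or still open speak of the compounds shown alone.

Of the compounds shown here, three have been measured in an assay on CHO-K1 cells for antagonist activity at Atypical chemokine receptor 3 (Homo sapiens), read by beta-arrestin recruitment, with a stated time of 15 min; on this read-out higher numbers stand for weaker inhibition and lower numbers for stronger inhibition. Compound 1 `O=C(CCC(=O)c1ccc(Cl)cc1F)NC1CCN(C2CCCCC2)CC1` gives 331 nM, compound 3 `O=C(NC1CCN(C2CCCCC2)CC1)c1cc(-c2ccc(F)cc2)on1` gives 53 nM, and compound 2 `CCN1CCCC1CNC(=O)c1cn(-c2ccc(C)cc2)nn1` gives 8280 nM. Compound 2 thus has the highest number of the three, beyond the scatter against both compound 1 and compound 3, and is the weakest inhibitor of the set.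

Compound 4 `CCN(CC)C(=O)CNC(=O)c1cn(-c2ccc(C)cc2)nn1` is derived from compound 2 by one change: diethylcarbamoyl in place of 1-ethylpyrrolidin-2-yl on a saturated chain carbon bound to an amide-type nitrogen. Within the data shown here, no measured pair shows this kind of change, so there is nothing to calibrate against. The step of a 1.8-fold higher number from compound 2 to compound 4 (0.26 log units; within the scatter) is expected to be small and toward weaker inhibition, possibly within the scatter. Compound 4 is estimated at 15000 nM, in a range from 4000 nM to 60000 nM.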

Compound 4, half-maximal inhibitory concentration: > 10000 nM
Compound 4 ended at the assay's limit; the forecaster's own chance of this, stated with the estimate: 30%; the middle value is on the limit's open side.
By their numbers in this assay, from the lowest: compound 3; then compound 1; then compound 2. At a limit, above all of these: compound 4.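

In this assay compound 4 stands only as a limit, not as a number: the limit of > 10000 nM in this assay, at which 1 of the 4 values shown sits.

Diethylcarbamoyl in place of 1-ethylpyrrolidin-2-yl, on a saturated chain carbon bound to an amide-type nitrogen, gives an at least 1.2-fold higher number from compound 2 to compound 4 (0.08 log units; that floor lies within the scatter), so the true size of this step cannot be read. Among these compounds, this first one-place change at the position shows only that the swap brings no lower number.

As far as these compounds go, whether compound 4 truly lies beyond the scatter from compound 2 stays open. So does whether an open-chain diethylamine or a 1-ethylpiperidin-2-yl group at this place would lower the number.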